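Swapping 1-methyl-1H-indol-5-yl for 4-acetylphenyl

This account rests on a few compounds, and the source may have more. Where it says the series, first, only, none or still open, it means among the compounds named here.

Going by the values given here, in a functional assay on A549 cells (Homo sapiens) for inhibition, read by CCK-8 assay, with a stated time of 48 h (a lower number here means a stronger inhibitor, a higher number a weaker inhibitor), compound 3 `COc1cc(-c2ccnc3cc(-c4ccc5c(ccn5C)c4)nn23)cc(OC)c1OC` gives 15 nM and stands lowest of the numbers so far. Compound 1 `COc1cc(-c2ccnc3cc(-c4ccc(Cl)cc4)nn23)cc(OC)c1OC` with its 4-chlorophenyl group gives 3070 nM and sits far higher. Compound 2 `COc1cc(-c2ccnc3cc(-c4cccc(C#N)c4)nn23)cc(OC)c1OC` with its 3-cyanophenyl group reads > 10000 nM and this is a limit of the assay, not a number. Compound 4 `COc1cc(-c2ccnc3cc(-c4ccc(C(C)=O)cc4)nn23)cc(OC)c1OC` carries 4-acetylphenyl in place of the 1-methyl-1H-indol-5-yl group of compound 3 (4-acetylphenyl in place of 1-methyl-1H-indol-5-yl on an aromatic carbon). Two measured steps run the opposite way and are large, one a 200-fold lower number from compound 1 to compound 3 (2.31 log units; beyond the scatter) and the other at least 660-fold lower number from compound 2 to compound 3 (2.82 log units; beyond the scatter) and both end on the 1-methyl-1H-indol-5-yl group. The smaller at least 3.2-fold higher number from compound 1 to compound 2 (0.51 log units; beyond the scatter) shows that the two phenyl groups themselves differ. Leaving the 1-methyl-1H-indol-5-yl group should therefore bring a large rise in this assay and the expected change is a 200-fold higher number from compound 3 to compound 4 (2.30 log units; beyond the scatter) in this estimate. For compound 4 the estimated value is 3000 nM with an expected range from 500 nM to 10000 nM at its upper end.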

Compound 4, half-maximal inhibitory concentration: 4100 nM
Compound 4: middle estimate off by 1.4-fold (0.14 log units), on the low side; the measured number falls inside the stated range.
By their numbers in this assay, from the lowest: compound 3; then compounds 1 and 4 (each within the scatter of the next). At a limit, above all of these: compound 2.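

In this assay, the new result shows that a para-free swap is not needed to see the loss: a 270-fold higher number from compound 3 to compound 4 (2.44 log units; beyond the scatter).

Correction of the final text:

In this assay, a second phenyl group bearing a single substituent also falls far short of the 1-methyl-1H-indol-5-yl group, with a 270-fold higher number from compound 3 to compound 4 (2.44 log units; beyond the scatter). Acetyl in place of chloro makes no difference beyond the scatter, with a 1.3-fold higher number from compound 1 to compound 4 (0.13 log units; within the scatter). The 4-acetylphenyl group does separate from 3-cyanophenyl, with an at least 2.4-fold lower number from compound 2 to compound 4 (0.38 log units; beyond the scatter), but that step rests on a limit of the assay: the limit of > 10000 nM in this assay, at which 1 of the 4 values shown sits.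

Still open, going by these compounds, is whether the indole needs the methyl group on its nitrogen. Also open, on these data alone, is whether a phenyl group carrying an amine at the 4-position could approach compound 3.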